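Swapping a hydroxyethyl chain for a methoxycyclohexyl ring

The source may report more compounds than this note shows. Statements on the series, on what has been measured and on what is new or still open speak of the compounds shown alone.

Measured compounds in a functional assay on LNCaP cells (Homo sapiens) for cytotoxicity; on this read-out higher numbers stand for weaker inhibition and lower numbers for stronger inhibition:
compound 1 `CNC(=O)Nc1ccc(-c2nc(N3CC4CCC(C3)O4)c3cnn(C)c3n2)cc1` gives 170 nM
compound 2 `CNC(=O)Nc1ccc(-c2nc(N3CC4CCC(C3)O4)c3cnn(CCN(C)C)c3n2)cc1` gives 400 nM
compound 3 `CNC(=O)Nc1ccc(-c2nc(N3CC4CCC(C3)O4)c3cnn(CCO)c3n2)cc1` gives 650 nM

Compound 3 stands at the highest, and therefore weakest, of the three numbers. Its step from compound 1 is a 3.8-fold higher number from compound 1 to compound 3 (0.58 log units; beyond the scatter), and its step from compound 2, a 1.6-fold higher number from compound 2 to compound 3 (0.21 log units; within the scatter), is within the scatter, so compounds 2 and 3 cannot be told apart.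

Compound 4 `CNC(=O)Nc1ccc(-c2nc(N3CC4CCC(C3)O4)c3cnn([C@H]4CC[C@@H](OC)CC4)c3n2)cc1` differs from compound 3 by 4-methoxycyclohexyl in place of 2-hydroxyethyl on an aromatic nitrogen. The change removes the hydrogen-bond donor of the 2-hydroxyethyl group and brings in a ring with more heavy atoms.

Going by the values given here, two measured steps touch the same position: a 2.4-fold higher number from compound 1 to compound 2 (0.37 log units; beyond the scatter) and a 3.8-fold higher number from compound 1 to compound 3 (0.58 log units; beyond the scatter), both modest losses on growing the group beyond a single carbon. The step of a 1.6-fold higher number from compound 2 to compound 3 (0.21 log units; within the scatter) shows that exchanging hydroxy for dimethylamino matters little. None of these steps covers a saturated ring, so the direction is uncertain. A step of a 2.6-fold lower number from compound 3 to compound 4 (0.41 log units; beyond the scatter) is expected, leaning toward a return to the range of compound 1, because 170 nM shows the smallest group gave the lowest number.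

Compound 4 is estimated at 250 nM, within 70 nM to 900 nM.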

Compound 4, half-maximal inhibitory concentration: 1 nM
Compound 4: the middle estimate sits 250-fold (2.40 log units) above what was measured; measured number below the stated range.
By their numbers in this assay, from the lowest: compound 4; then compound 1; then compounds 2 and 3 (each within the scatter of the next).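

In this assay, going by these compounds alone, the group on the aromatic nitrogen proves to have far more influence on the number than the earlier compounds suggested: 4-methoxycyclohexyl gives a 650-fold lower number from compound 3 to compound 4 (2.81 log units; beyond the scatter) against 2-hydroxyethyl, a 400-fold lower number from compound 2 to compound 4 (2.60 log units; beyond the scatter) against 2-(dimethylamino)ethyl and a 170-fold lower number from compound 1 to compound 4 (2.23 log units; beyond the scatter) against methyl. The earlier impression that a group larger than methyl raises the number fits compound 2 and compound 3, but compound 4 goes against it, since it carries the largest group shown and has the lowest number of the four. The change brings in a six-membered carbon ring, removes the hydrogen-bond donor and adds heavy atoms all at once, and nothing available here accounts for the size of the drop.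

On these data alone, it stays open whether the ring, the methoxy group or their spatial arrangement matters most; a plain cyclohexyl, a 4-hydroxycyclohexyl or the other stereoisomer of 4-methoxycyclohexyl would help separate these. As far as these compounds go, it also stays open whether an open-chain ether such as 2-methoxyethyl would bring any of the same drop, or whether a ring is needed.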